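The compounds below may be only part of what the source reports. "The series", "measured", "known", "first", "only" and "open" are said of these compounds alone.

Two compounds have been measured so far in an ADME assay on microsomes from liver (Rattus norvegicus) for metabolic stability, read by LC-MS, using NADPH, with a stated time of 10 min, tested at 0.1 uM (on this read-out higher numbers stand for fast clearance and lower numbers for slow clearance), for this series:

- compound 1 `COc1ccc(F)cc1N1C(=O)CSC1c1cccc(C(=O)NCCCCn2cccn2)c1` with 1470 mL.min-1.g-1 
- compound 2 `COc1ccc(F)cc1N1C(=O)CSC1c1cccc(C(=O)NCCCCc2ccccc2)c1` with 2300 mL.min-1.g-1 

Compound 1 and compound 2 lie within the scatter of each other. Compound 3 `O=C(NCCCCn1cccn1)c1cccc(C2SCC(=O)N2c2ccccn2)c1` is not yet measured, and the change pyridin-2-yl in place of 5-fluoro-2-methoxyphenyl on an amide-type nitrogen in a ring puts pyridin-2-yl in place of 5-fluoro-2-methoxyphenyl on an amide-type nitrogen in a ring. Within the data shown here, no measured step touches this place. Among the measured compounds shown here, the only step at hand, a 1.6-fold higher number from compound 1 to compound 2 (0.19 log units; within the scatter) and made elsewhere in the molecule, gives a poor guide, so a step no larger than the scatter is expected in this assay without a firm direction. The estimate means a 1.3-fold lower number from compound 1 to compound 3 (0.13 log units; within the scatter) as the expected step. Compound 3 is expected at 1100 mL.min-1.g-1 between 400 mL.min-1.g-1 and 2600 mL.min-1.g-1 as the estimated range.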

Compound 3, intrinsic clearance in microsomes: 506 mL.min-1.g-1
Beside the measured number, compound 3's estimate is 2.2-fold (0.34 log units) above it; low and high end bracket the measured number.
By their numbers in this assay, from the lowest: compound 3; then compounds 1 and 2 (each within the scatter of the next).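

In this assay the group on the amide-type nitrogen in the ring proves able to move the read-out: pyridin-2-yl in place of 5-fluoro-2-methoxyphenyl gives a 2.9-fold lower number from compound 1 to compound 3 (0.46 log units; beyond the scatter) and is the only step shown beyond the scatter. No measurement given here accounts for this step.

The compounds leave open whether the ring nitrogen or the loss of the methoxy and fluoro groups matters, which pyridin-3-yl or unsubstituted phenyl at this place could separate. As far as these compounds go, whether the step carries over to the phenyl chain end of compound 2 also remains open.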